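The source may hold more compounds than are shown below. What is called first, only, known or untested is meant among the compounds shown, and "the series" means these compounds.

Measured compounds:
compound 1 `COc1ccc(S(=O)(=O)N2CCc3cccc(NC(=O)c4ccc([N+](=O)[O-])cc4)c32)cc1` gives 95 nM in a functional assay on MKN-45 cells (Homo sapiens) for cytotoxicity; on this read-out higher numbers stand for weaker inhibition and lower numbers for stronger inhibition
compound 2 `COc1ccc(S(=O)(=O)N2CCc3cccc(NC(=O)c4ccccc4)c32)cc1` gives 250 nM in this assay
compound 3 `COc1ccc(S(=O)(=O)N2CCc3cccc(NS(=O)(=O)c4ccccc4)c32)cc1` gives 562 nM in this assay

Among these three, compound 3 has the highest number, and its steps to both others lie beyond the scatter. The cores of compound 2 and compound 3 differ by phenylsulfonyl in place of benzoyl on a nitrogen on an aromatic ring, a step of a 2.2-fold higher number from compound 2 to compound 3 (0.35 log units; beyond the scatter). The change nitro in place of hydrogen on an aromatic carbon gave a 2.6-fold lower number from compound 2 to compound 1 (0.42 log units; beyond the scatter). Compound 4 `COc1ccc(S(=O)(=O)N2CCc3cccc(NS(=O)(=O)c4ccc([N+](=O)[O-])cc4)c32)cc1` carries the same change on the core of compound 3: nitro in place of hydrogen on an aromatic carbon. This change occurs twice among the compounds here, with the place described in the same words both times. Among the compounds with values here, for compound 4 a step of a 2.4-fold lower number from compound 3 to compound 4 (0.39 log units; beyond the scatter) in this assay is expected, resting on the single precedent a 2.6-fold lower number from compound 2 to compound 1 (0.42 log units; beyond the scatter); with one example the size is uncertain. Compound 4 is estimated at 230 nM, between 110 nM and 500 nM.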

Compound 4, half-maximal inhibitory concentration: 933 nM
Compound 4: middle estimate off by 4.1-fold (0.61 log units), on the low side, and the stated range ends below it.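

On the phenylsulfonyl core, nitro in place of hydrogen gives a 1.7-fold higher number from compound 3 to compound 4 (0.22 log units; within the scatter) and so does not repeat the clear step seen on the benzoyl core. In this assay, the effect of this change therefore does not carry over between these two cores: the same change on two cores in this assay, a 2.6-fold lower number (0.42 log units; beyond the scatter) from compound 2 to compound 1 and a 1.7-fold higher number (0.22 log units; within the scatter) from compound 3 to compound 4, 4.4-fold (0.64 log units) apart, beyond the scatter of two such steps
Within the data shown here, with only two pairs, this shows that the step cannot be assumed to transfer, but not what sets the two cores apart or how other cores would behave.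

Still open, on these data alone, is whether an amine or a carboxylic acid in the same place, para to a large group, would also differ between the two cores. A longer chain in place of the phenyl or 4-nitrophenyl group also remains to be placed in this comparison.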